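Replacing One Phenyl Group in a Growth Inhibitor Series

A few compounds are considered here, and "the series" means these few. Any claim that something is new, unique, unknown or untested is made for them only; others in the source may bear on it.

In a functional assay on DU-145 cells (Homo sapiens) for inhibition, read by trypan blue exclusion, with a stated time of 96 h (on this read-out higher numbers stand for weaker inhibition of growth and lower numbers for stronger inhibition of growth), compound 1 `O=C(O)c1ccc(C(=O)/C(=C\c2ccc(O)c([N+](=O)[O-])c2)SCc2ccc(Br)cc2)cc1` gives 50000 nM while compound 2 `COc1cc(/C=C(/SCc2ccc(Br)cc2)C(=O)c2ccc(C(=O)O)cc2)ccc1F` gives 1000 nM and compound 3 `O=C(O)c1ccc(C(=O)/C(=C\c2ccc(Br)c([N+](=O)[O-])c2)SCc2ccc(Br)cc2)cc1` gives 1000 nM as its result. Compound 3 therefore stands level with compound 2, and the two share the lowest number of the three.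

Compound 4 `O=C(O)c1ccc(C(=O)/C(=C\c2ccccc2F)SCc2ccc(Br)cc2)cc1` has not yet been measured. It differs from compound 3 by 2-fluorophenyl in place of 4-bromo-3-nitrophenyl on a double-bonded chain carbon bound to a double-bonded chain carbon in a single place, on a double-bonded chain carbon bound to a double-bonded chain carbon, where 2-fluorophenyl stands in place of 4-bromo-3-nitrophenyl.

The measured steps at this place are a 50-fold lower number from compound 1 to compound 2 (1.70 log units; beyond the scatter) and a 50-fold lower number from compound 1 to compound 3 (1.70 log units; beyond the scatter) together with no change at the digits printed from compound 2 to compound 3 (within the scatter) as the third. Both large steps start from compound 1, the only one of the three with a hydroxy group, and compound 4 has none. It is thus expected to lie nearer compound 3 at 1000 nM than compound 1 at 50000 nM on this scale. Going by the values given here, no measured compound carries 2-fluorophenyl, so some loss of growth inhibition is allowed for.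

The expected change is a 2.5-fold higher number from compound 3 to compound 4 (0.40 log units; beyond the scatter) by this estimate, small beside the large steps. For compound 4 the estimated value is 2500 nM with an expected range from 700 nM to 12000 nM in this assay once it is measured.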

Compound 4, concentration for 50% growth inhibition: 10000 nM
Compound 4: the middle estimate sits 4.0-fold (0.60 log units) below what was measured; the range from low to high includes it.
By their numbers in this assay, from the lowest: compounds 2 and 3 (each within the scatter of the next); then compound 4; then compound 1.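

In this assay, the 2-fluorophenyl group also carries no hydroxy group, and a 5.0-fold lower number from compound 1 to compound 4 (0.70 log units; beyond the scatter), yet it does not reach the level of the other two groups without a hydroxy group: a 10-fold higher number from compound 3 to compound 4 (1.00 log units; beyond the scatter) and a 10-fold higher number from compound 2 to compound 4 (1.00 log units; beyond the scatter). The earlier compounds shown here showed two quite different phenyl groups, 4-fluoro-3-methoxyphenyl and 4-bromo-3-nitrophenyl, giving the same number, so this place could have seemed tolerant of any change once the hydroxy group was gone, but compound 4 shows that it still separates such groups. The entering group has fewer heavy atoms and fewer hydrogen-bond acceptors than the group it replaces, but several things change together in this step, so no single one can be picked out as the one that matters.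

A plain phenyl group and a phenyl group bearing an amine would help show whether the fluorine or the missing nitro and bromo groups account for the step from compound 3 to compound 4. Nothing available here gives a measured reason for the differences seen at this place.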